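A few compounds are considered here, and "the series" means these few. Any claim that something is new, unique, unknown or untested is made for them only; others in the source may bear on it.

Measured compounds:
compound 1 `CCOCCC(=O)NCC(=O)N[C@@H]1[C@@H](O)[C@H](O)[C@@H](Nc2ncnc3[nH]cnc23)O[C@H]1C`, > 1000 uM
compound 2 `CCCCCCCCCCCC(=O)NCC(=O)N[C@@H]1[C@@H](O)[C@H](O)[C@@H](Nc2ncnc3[nH]cnc23)O[C@H]1CO`, 5.5 uM

Among the measured compounds shown here, compound 2 is the only compound with a number in a functional assay on L1210 cells (Mus musculus) for inhibition, with a stated time of 3 h; a higher number here means that more compound is needed for the effect, a lower number that less compound is needed; in this assay compound 2 gives 5.5 uM. For compound 1 the result is a limit of the assay, (the limit of > 1000 uM in this assay, at which 1 of the 2 values shown sits).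

Compound 3 `CCOCCC(=O)NCC(=O)N[C@@H]1[C@@H](O)[C@H](O)[C@@H](Nc2ncnc3[nH]cnc23)O[C@H]1CO` differs from compound 2 by ethoxy in place of nonyl on a saturated chain carbon, two bonds along the chain from a carbonyl carbon. Compound 1 already carries the ethoxy chain of compound 3, and compound 1 reaches only a limit. For the measured compounds named here, no measured step covers this change, so the expectation rests on what those two values show: a large loss from compound 2 to compound 3 is expected, a 91-fold higher number from compound 2 to compound 3 (1.96 log units; beyond the scatter). For compound 3 the estimate in this assay is 500 uM, within 50 uM to 3000 uM.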

Compound 3, concentration for half-maximal effect: > 1000 uM
Compound 3 gave a limit, no number (the forecaster's own chance of this, stated with the estimate: 65%); middle value at least 2.0-fold (0.30 log units) from the limit.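

Ethoxy in place of nonyl on a saturated chain carbon, two bonds along the chain from a carbonyl carbon, gives an at least 180-fold higher number from compound 2 to compound 3 (2.25 log units; beyond the scatter) in this assay. Among the compounds shown here, this is the first measured step at this position, and it shows that the change carries a large loss with the hydroxy group kept in place. The result for compound 3 is a limit of the assay, so the full size of that loss and the step from compound 1 cannot be read: the limit of > 1000 uM in this assay, at which 2 of the 3 values shown sit.

The compounds shown leave open how a butyl or hexyl chain would fare in this place. They also leave open what an amine or a carboxylic acid would give there.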